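A Smaller Aryl Group on the Shared Core

The source may hold more compounds than are shown below. What is called first, only, known or untested is meant among the compounds shown, and "the series" means these compounds.

In a functional assay on cells (Panel breast (Carcinoma cell lines), Homo sapiens) for inhibition, read by sulforhodamine B assay, with a stated time of 48 h (on this read-out higher numbers stand for lower toxicity in this test and lower numbers for higher toxicity in this test), compound 1 (`CN1CCN(CCCOc2cccc3nc(Nc4ccc(Cl)c(C(F)(F)F)c4)ccc23)CC1`) gives 11200 nM and compound 2 (`CN1CCN(CCCOc2cccc3nc(Nc4ccc(F)c(F)c4)ccc23)CC1`) gives 20300 nM as a pair lying within the scatter of each other. Compound 3 (`CN1CCN(CCCOc2cccc3nc(Nc4cccc(Cl)c4)ccc23)CC1`) differs from compound 1 in one place, with 3-chlorophenyl in place of 4-chloro-3-(trifluoromethyl)phenyl on a nitrogen on an aromatic ring. Among the compounds with values here, the one measured step at that place is a 1.8-fold higher number from compound 1 to compound 2 (0.26 log units; within the scatter) and stays within the scatter, so no step beyond the scatter is expected in this assay for this change. The expected step is a 1.3-fold higher number from compound 1 to compound 3 (0.13 log units; within the scatter) on this estimate. Compound 3 is estimated at 15000 nM with an expected range from 7500 nM to 30000 nM as its upper end.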

Compound 3, concentration lethal to 50% of the cells: 20800 nM
For compound 3 the middle estimate is 1.4-fold (0.14 log units) below the measured one; the measured number falls inside the stated range.
By their numbers in this assay, from the lowest: compounds 1, 2 and 3 (each within the scatter of the next).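

In this assay, a second replacement at this place, the smaller 3-chlorophenyl in place of 4-chloro-3-(trifluoromethyl)phenyl, gives a 1.9-fold higher number from compound 1 to compound 3 (0.27 log units; within the scatter) and so also stays within the scatter. Set against 3,4-difluorophenyl, the same group gives a 1.0-fold higher number from compound 2 to compound 3 (0.01 log units; within the scatter), so this read-out does not separate the three aryl groups shown. Nothing available bears on why these groups are not separated. The compounds shown leave open whether a carboxylic acid or an amine on the phenyl ring would give a step beyond the scatter.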